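A few compounds are considered here, and "the series" means these few. Any claim that something is new, unique, unknown or untested is made for them only; others in the source may bear on it.

Measured compounds:
Compound 1 `O=C(/C=C1\CCc2ccc(F)cc21)NCC1CC1`: 0%
Compound 2 `O=C(/C=C1\CCc2ccc(F)cc21)N1CCCC1`: 10%
Compound 3 `O=C(/C=C1\CCc2ccc(F)cc21)NC1CCC1`: 4%

All three share one core and differ only in the group attached to the carbonyl carbon. In a functional assay on the whole organism with Rattus norvegicus as the target, at a dose of 20 mg/kg by the oral route (a lower number here means less inhibition, a higher number more inhibition at the dose given (going by the name of the read-out)), compound 3 gives 4%, and its number sits close to both of the others: the change is a number 4 percentage points higher from compound 1 to compound 3 (within the scatter) and a number 6 percentage points lower from compound 2 to compound 3 (within the scatter), so none of the three can be told apart on these data.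

The next compound, compound 4 `O=C(/C=C1\CCc2ccc(F)cc21)N1CCC1`, arises from compound 3 by the change (azetidin-1-yl in place of cyclobutylamino on a carbonyl carbon). Among the measured compounds shown here, two measured steps bear on this kind of change. Going from an open amino group to a ring-closed amine gave a number 10 percentage points higher from compound 1 to compound 2 (within the scatter), and the reverse move, opening a ring-closed amine into an amino group, gave a number 6 percentage points lower from compound 2 to compound 3 (within the scatter); neither rose above the scatter. Closing the ring once more in compound 4 is therefore expected to leave the read-out where the others lie, with a step of a number 1 percentage points higher from compound 3 to compound 4 (within the scatter) in this assay. The estimate for compound 4 in this assay is 5%, with a likely range from 0% to 15%.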

Compound 4, a percentage reported as inhibition, in the whole organism at one dose (the size of the read-out at that dose, not a potency): 14%
Beside the measured number, compound 4's estimate is 9 percentage points below it; the range from low to high includes it.
By their numbers in this assay, from the lowest: compounds 1, 3, 2 and 4 (each within the scatter of the next, the first and the last beyond it).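

In this assay, among the compounds shown here, the only step in this set that clears the scatter is a number 14 percentage points higher from compound 1 to compound 4 (beyond the scatter), a modest change that replaces (cyclopropylmethyl)amino with azetidin-1-yl on the carbonyl carbon. The two other new steps stay inside the scatter, a number 10 percentage points higher from compound 3 to compound 4 (within the scatter) and a number 4 percentage points higher from compound 2 to compound 4 (within the scatter), so azetidin-1-yl can be told apart from (cyclopropylmethyl)amino but not from cyclobutylamino or pyrrolidin-1-yl, and this position has so far shown only a small separation between the two ends of the set. Nothing available explains why this one pair separates.

The compounds shown leave open whether a different kind of group on the carbonyl carbon, such as a morpholin-4-yl ring or a longer open chain like n-butylamino, would move the read-out further than azetidin-1-yl does. They also leave open whether the gap between compound 1 and compound 4 would persist at other oral doses, as every number here comes from a single dose and reports the size of the effect at that dose, not a potency.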